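Phenyl for nitrophenyl on a fused aromatic core

The compounds below may be only part of what the source reports. "The series", "measured", "known", "first", "only" and "open" are said of these compounds alone.

Compound 1, `Cc1nc2c3ccccc3ccc2c2nc3c(ccc4ccccc43)c(-c3cccc([N+](=O)[O-])c3)c12`: 13200 nM
Compound 2, `Cc1nc2c3ccccc3ccc2c2nc3c(ccc4ccccc43)c(-c3nccnc3N)c12`: 3560 nM

Of the compounds shown here, two sharing one core have been measured in a functional assay on HCT-116 cells (Homo sapiens) for cytotoxicity, read by MTT assay, with a stated time of 48 h; on this read-out lower numbers stand for stronger inhibition and higher numbers for weaker inhibition. Compound 1 gives 13200 nM, the highest of the two numbers, and compound 2 gives 3560 nM. Among the compounds with values here, the only step recorded is a 3.7-fold lower number from compound 1 to compound 2 (0.57 log units; beyond the scatter), which is a modest change that reaches beyond the scatter and comes from swapping 3-aminopyrazin-2-yl in for 3-nitrophenyl on an aromatic carbon.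

Compound 3, `Cc1nc2c3ccccc3ccc2c2nc3c(ccc4ccccc43)c(-c3ccccc3)c12`, has not yet been tested in this assay. It differs from compound 1 by hydrogen in place of nitro on an aromatic carbon, on a six-membered aromatic ring of carbon only, meta to a large group; seen one bond further out, 3-nitrophenyl becomes phenyl. Within the data shown here, no measured step removes the nitro while keeping the phenyl ring, so the one step that exists bears on it only loosely, and nothing in the data points to a clear direction. The expected step is a 1.1-fold lower number from compound 1 to compound 3 (0.04 log units; within the scatter), that is, no change beyond the scatter. Compound 3 is therefore estimated at 12000 nM, with a range from 5000 nM to 30000 nM.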

Compound 3, half-maximal inhibitory concentration: > 80000 nM
Compound 3 was reported as a limit (the forecaster's own chance of this, stated with the estimate: 10%); middle value at least 6.6-fold (0.82 log units) from the limit.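

In this assay compound 3 is reported only as a limit and not as a number: the limit of > 80000 nM in this assay, at which 1 of the 3 values shown sits. Taking the nitro off the ring gives an at least 6.0-fold higher number from compound 1 to compound 3 (0.78 log units; beyond the scatter) and putting phenyl in place of 3-aminopyrazin-2-yl gives an at least 22-fold higher number from compound 2 to compound 3 (1.35 log units; beyond the scatter) here, so the unsubstituted phenyl ends up on the weak side of both substituted rings shown. Within the data shown here, the earlier pair showed only that one substituted ring differs from another, whereas this result shows that what the ring carries at this position matters, and that the nitro of compound 1, weak as that compound is, counts for something in this cell read-out.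

From the compounds shown here alone, how far compound 3 really lies from the other two stays unknown, and so does whether the nitro is special or whether an amine, a methoxy group or a chlorine in the same place on the phenyl ring would serve as well. For compound 2, a plain pyrazin-2-yl and a 3-aminophenyl group would be needed to separate the part played by the amine from that of the ring nitrogens.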